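The source may report more compounds than this note shows. Statements on the series, on what has been measured and on what is new or still open speak of the compounds shown alone.

Compounds measured so far:
compound 1 `CCOC(=O)C(C)(C)Oc1ccc2c(=O)cc(-c3cc(C(C)(C)C)c(O)c(C(C)(C)C)c3)oc2c1` — 3000 nM
compound 2 `CC(C)(C)c1cc(-c2cc(=O)c3ccc(O)cc3o2)cc(C(C)(C)C)c1O` — 1000 nM

In a functional assay for inhibition (a lower number here means a stronger inhibitor, a higher number a weaker inhibitor), compound 2 stands lowest of the two numbers, with compound 1 the nearest; the step of a 3.0-fold lower number from compound 1 to compound 2 (0.48 log units; beyond the scatter) is the only one measured at that oxygen. Compound 3 `CC(C)(C)c1cc(-c2cc(=O)c3ccc(OCC(O)CO)cc3o2)cc(C(C)(C)C)c1O` differs from compound 2 in one place: 2,3-dihydroxypropyl in place of hydrogen on an oxygen on an aromatic ring. For the measured compounds named here, the one step that bears on it shows a substituent on this oxygen carrying a higher number than hydrogen, so a modest rise is expected in this assay, though the entering group is smaller than the one that left. Compound 3 is estimated at 2000 nM (range 800 nM to 6000 nM), meaning an expected step of a 2.0-fold higher number from compound 2 to compound 3 (0.30 log units; within the scatter).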

Compound 3, half-maximal inhibitory concentration: 100 nM
Beside the measured number, compound 3's estimate is 20-fold (1.30 log units) above it; the measured number lies below the stated range.
By their numbers in this assay, from the lowest: compound 3; then compound 2; then compound 1.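

In this assay, a group on this oxygen need not cost anything: 2,3-dihydroxypropyl in place of hydrogen gives a 10-fold lower number from compound 2 to compound 3 (1.00 log units; beyond the scatter), the opposite direction to a 3.0-fold lower number from compound 1 to compound 2 (0.48 log units; beyond the scatter). The two substituted compounds are separated by a 30-fold lower number from compound 1 to compound 3 (1.48 log units; beyond the scatter), so across these compounds the outcome follows the identity of the group, not the mere presence of one. No measurement available here bears on the reason for this result.

Open, from the compounds shown here alone, is whether the hydroxy groups of the chain are required, as a plain propyl chain would test. Also open, going by these compounds, is whether an amine or a carboxylic acid at the end of a chain on this oxygen would track compound 3 or compound 1.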